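A Third Methoxy Group and the Tolerated Concentration

The source may hold more compounds than are shown below. What is called first, only, known or untested is meant among the compounds shown, and "the series" means these compounds.

Within the data shown here, compound 2 `COc1ccc(/C=C/C(=O)c2c(C)[n+]([O-])c3ccccc3[n+]2[O-])cc1OC` stands with the higher of the two numbers measured so far in a functional assay on HSC-4 cells (Homo sapiens) for cytotoxicity, with a stated time of 48 h; a lower number here means that less compound is tolerated, a higher number that more compound is tolerated: in this assay compound 2 gives 38000 nM. Its nearest neighbour, compound 1 `COc1ccc(/C=C/C(=O)c2c(C)[n+]([O-])c3ccccc3[n+]2[O-])cc1`, gives 11000 nM in this assay, and the step between them, a 3.5-fold higher number from compound 1 to compound 2 (0.54 log units; beyond the scatter), came from a methoxy in place of hydrogen on an aromatic carbon. Among the measured compounds shown here, that is the only measured step, and it is modest but beyond the scatter.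

Compound 3 `COc1cc(/C=C/C(=O)c2c(C)[n+]([O-])c3ccccc3[n+]2[O-])cc(OC)c1OC` differs from compound 2 by methoxy in place of hydrogen on an aromatic carbon. For the measured compounds named here, the one step that bears on this change is a 3.5-fold higher number from compound 1 to compound 2 (0.54 log units; beyond the scatter), in which a methoxy group entered the same ring. Going by the values given here, because that step, a 3.5-fold higher number from compound 1 to compound 2 (0.54 log units; beyond the scatter), raised the number, a further methoxy on this ring is expected to move the number in the same direction, by a step of similar or somewhat smaller size, a 2.1-fold higher number from compound 2 to compound 3 (0.32 log units; beyond the scatter), though with only a single precedent the uncertainty is wide. Compound 3 is therefore expected to give 80000 nM in this assay, with a likely range from 25000 nM to 250000 nM.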

Compound 3, half-maximal cytotoxic concentration: 6500 nM
Beside the measured number, compound 3's estimate is 12-fold (1.09 log units) above it; measured number below the stated range.
By their numbers in this assay, from the lowest: compounds 3 and 1 (each within the scatter of the next); then compound 2.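

In this assay, the same replacement of hydrogen by methoxy on the six-membered aromatic ring does not have a fixed direction: the earlier change gave a 3.5-fold higher number from compound 1 to compound 2 (0.54 log units; beyond the scatter) and the number rose, whereas the new change gave a 5.8-fold lower number from compound 2 to compound 3 (0.77 log units; beyond the scatter) and the number fell. Among these compounds, this new methoxy sits ortho to a methoxy group, meta to a methoxy group and meta to a large group, so the direction of this change depends on where the group enters, on the methoxy groups already on the ring, or on both, which the single earlier step could not show. Nothing available explains this reversal.

The compounds shown leave open whether the fall belongs to methoxy itself or would follow any group entering at this place. A hydroxyl group, an amine or a longer chain such as ethoxy in the same place would test this, as would a methoxy at this place with the neighbouring methoxy groups replaced by hydrogen.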